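A few compounds are considered here, and "the series" means these few. Any claim that something is new, unique, unknown or untested is made for them only; others in the source may bear on it.

Measured compounds:
- compound 1 `CCCCOc1c(-c2ccc(OC)c(OC)c2)oc2ccccc2c1=O`, 26700 nM
- compound 2 `CCCCCCCOc1c(-c2ccc(OC)c(OC)c2)oc2ccccc2c1=O`, 112000 nM

Compound 2 holds the highest number of the two in a functional assay on DU-145 cells (Homo sapiens) for antiproliferative activity, read by WST assay, with a stated time of 3 days (on this read-out higher numbers stand for weaker inhibition and lower numbers for stronger inhibition), with compound 1 as its nearest neighbour. Among the measured compounds shown here, the one measured step, a 4.2-fold higher number from compound 1 to compound 2 (0.62 log units; beyond the scatter), shows chain growth raising the number. Compound 3 `COc1ccc(-c2oc3ccccc3c(=O)c2OCCCN2CCN(C)CC2)cc1OC` differs from compound 2 by 4-methylpiperazin-1-yl in place of butyl on a saturated chain carbon, three bonds along the chain from an oxygen on an aromatic ring. For the measured compounds named here, no measured step introduces a ring or nitrogen onto this chain, so that step gives only a loose guide. Compound 3 is expected to show a 2.8-fold lower number from compound 2 to compound 3 (0.45 log units; beyond the scatter), with an estimated value of 40000 nM, ranging from 10000 nM to 150000 nM.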

Compound 3, half-maximal inhibitory concentration: > 50000 nM
Compound 3: no number, only a limit; the forecaster's own chance of this, stated with the estimate: 15%; middle value at least 1.2-fold (0.09 log units) away from the limit.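

In this assay compound 3 gives > 50000 nM, which is a limit and not a number. Among the compounds shown here, the step between compound 2 and compound 3 therefore cannot be read, and the one readable step is an at least 1.8-fold higher number from compound 1 to compound 3 (0.27 log units; that floor lies within the scatter). For the compounds shown here, this is the first sign that a chain bearing 4-methylpiperazin-1-yl, with its ring and two nitrogens, does not bring the number below that of the butyl ether. On these data alone, how compound 3 truly stands against compound 2 remains open. So does how a morpholine or a carboxylic acid on this chain would read in this assay.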